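The compounds below may be only part of what the source reports. "The series", "measured", "known", "first", "only" and "open" are said of these compounds alone.

Measured so far:
Compound 1 `CCCC(CCOc1ccc(-c2ccc(Cl)cc2)cc1)CCN1CCN(c2ccncc2)C1=O`. In an ADME assay on cells (Homo sapiens) for cytotoxicity (on this read-out lower numbers stand for higher toxicity in this test and higher numbers for lower toxicity in this test), compound 1 gives > 25000 nM, which is a limit of the assay and not a number.
Compound 2 `CCc1nc(-c2ccc(OCCC(C)CCN3CCN(c4ccncc4)C3=O)cc2)no1`. In this assay compound 2 gives > 25000 nM, again a limit of the assay rather than a number.

Compound 1 therefore stands at the edge of what this assay can report; both values shown sit there, as the evidence states (the limit of > 25000 nM in this assay, at which 2 of the 2 values shown sit). Among the measured compounds shown here, no step between two measured compounds is available, so nothing within these data says how a change of structure moves this read-out.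

Compound 3 `O=C1N(CCC(CCOc2ccc(-c3ccc(Cl)cc3)cc2)Cc2ccccc2)CCN1c1ccncc1` differs from compound 1 in one place: phenyl in place of ethyl on a saturated chain carbon, four bonds along the chain from an amide-type nitrogen in a ring and an oxygen on an aromatic ring. Since the only anchor is a limit, the expectation for this step rests on the structural change alone. He expects the step from compound 1 to compound 3 to be small, towards somewhat higher toxicity, and likely still within the usual scatter of the assay: an at least 1.2-fold lower number from compound 1 to compound 3 (0.09 log units; that floor lies within the scatter). On that basis compound 3 is estimated at 20000 nM in this assay, with a range from 8000 nM to 40000 nM, and a fair chance that the assay once more reports only a limit.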

Compound 3, half-maximal cytotoxic concentration: > 10000 nM
Compound 3 was reported as a limit; the forecaster's own chance of this, stated with the estimate: 55%; the middle value does not contradict the limit.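

In this assay the results for compound 1 and compound 3 are both limits of the assay and not numbers, so no size can be read for the step between them, which puts phenyl in place of ethyl. The compounds shown leave open whether that change moves this read-out at all, and in which direction.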